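Methoxy in Place of Amino: What to Expect for Compound 3

This account rests on a few compounds, and the source may have more. Where it says the series, first, only, none or still open, it means among the compounds named here.

Compound 1 `Nc1cccc(-c2cnc3[nH]cc(-c4ccncc4)c3c2)c1`: 42.7 nM
Compound 2 `Cc1ccc(-c2cnc3[nH]cc(-c4ccncc4)c3c2)cc1N`: 22.2 nM

In an assay on isolated protein for inhibition of high affinity nerve growth factor receptor (Homo sapiens), read by 33P incorporation (a higher number here means a weaker inhibitor, a lower number a stronger inhibitor), compound 1 gives 42.7 nM, the upper end of the two numbers, with compound 2 nearest at a 1.9-fold lower number from compound 1 to compound 2 (0.28 log units; within the scatter). Compound 3 `COc1cccc(-c2cnc3[nH]cc(-c4ccncc4)c3c2)c1` differs from compound 1 by methoxy in place of amino on an aromatic carbon. Within the data shown here, the one measured step adds a methyl and keeps the amino, so it does not bear on this exchange; no measured step does. With no guide in the data, only a modest shift in this assay is expected, if any, and with wide uncertainty. The estimate for compound 3 is 80 nM, within 25 nM to 300 nM. That expectation corresponds to a 1.9-fold higher number from compound 1 to compound 3 (0.27 log units; within the scatter).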

Compound 3, half-maximal inhibitory concentration: 22.7 nM
Compound 3: middle estimate off by 3.5-fold (0.55 log units), on the high side, and the stated range ends above it.
By their numbers in this assay, from the lowest: compounds 2, 3 and 1 (each within the scatter of the next).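

Methoxy can stand in place of amino at this position, on a six-membered aromatic ring of carbon only and meta to a large group, with a 1.9-fold lower number from compound 1 to compound 3 (0.27 log units; within the scatter) in this assay. The exchange goes from amino, with 1 hydrogen-bond donor, to methoxy, with 0 hydrogen-bond donors, and the result stays within the scatter, something compounds 1 and 2, which both keep the amino, could not show. Nothing available explains this result.

The compounds shown leave open how a hydroxyl, an ethoxy or a carboxylic acid would read at this place in this assay, and whether methoxy would read the same with the added methyl of compound 2 present.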